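The source may hold more compounds than are shown below. What is called first, only, known or untested is meant among the compounds shown, and "the series" means these compounds.

Compound 2 `CC(C)(N)CC(=O)N[C@@H]1CCc2ccccc2N(Cc2ccc(-c3ccccc3-c3nnn(Cc4ccccc4)n3)cc2)C1=O` belongs to a small series of three measured compounds. In a functional assay (Pituitary gland cell) with Rattus norvegicus as the target (on this read-out higher numbers stand for an effect only at larger amounts of compound and lower numbers for an effect already at smaller amounts), compound 2 gives 1 uM. Compound 3 `Cc1ccccc1-c1ccc(CN2C(=O)[C@H](NC(=O)CC(C)(C)N)CCc3ccccc32)cc1` gives 1 uM, and with no change at the digits printed from compound 2 to compound 3 (within the scatter) the two stand level, together the lowest of the three numbers. Compound 1 `CC(C)(N)CC(=O)N[C@@H]1CCc2ccccc2N(Cc2ccc(-c3ccccc3C(=O)O)cc2)C1=O`, which carries a carboxy group at the same place, gives 3 uM; from it there is a 3.0-fold lower number from compound 1 to compound 2 (0.48 log units; beyond the scatter) and a 3.0-fold lower number from compound 1 to compound 3 (0.48 log units; beyond the scatter). Compound 4 `CC(C)(N)CC(=O)N[C@@H]1CCc2ccccc2N(Cc2ccc(-c3ccccc3C(N)=O)cc2)C1=O` has not yet been measured. It differs from compound 2 in one place: carbamoyl in place of 2-benzyl-2H-tetrazol-5-yl on an aromatic carbon. Going by the values given here, the steps that bear on this change are the two in which the carboxy group of compound 1 was replaced, each a modest step beyond the scatter. Among the compounds with values here, no measured step introduces a carbamoyl group. The expectation is a modest rise in the number for compound 4 relative to compound 2, because compound 1 gives 3 uM with a carboxy group at this place. For compound 4 the estimated value in this assay is 2 uM, with a range from 0.7 uM to 6 uM. This estimate corresponds to an expected step of a 2.0-fold higher number from compound 2 to compound 4 (0.30 log units; within the scatter).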

Compound 4, concentration for half-maximal effect: 0.08 uM
Compound 4: middle estimate off by 25-fold (1.40 log units), on the high side; the whole stated range lies above it.
By their numbers in this assay, from the lowest: compound 4; then compounds 2 and 3 (each within the scatter of the next); then compound 1.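

Going by these compounds alone, the carbamoyl group shows that this place, on an aromatic carbon ortho to a large group, can shift the number far more than the earlier compounds suggested: in this assay there is a 13-fold lower number from compound 2 to compound 4 (1.10 log units; beyond the scatter) and a 13-fold lower number from compound 3 to compound 4 (1.10 log units; beyond the scatter), both large steps, whereas compounds 2 and 3 had stood level. The carbonyl alone does not set the result, since amino in place of hydroxy on that carbonyl carbon gives a 38-fold lower number from compound 1 to compound 4 (1.57 log units; beyond the scatter), also a large step. Among these compounds, only the carbamoyl group stands apart from the other three groups at this place.

From the compounds shown here alone, it remains open whether a nitrile, a methylcarbamoyl group or a carbamoylmethyl chain at this place would give a similarly low number. No measurement shown here accounts for the size of these steps.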